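Swapping the sulfonyl substituent in a urea series

The source may hold more compounds than are shown below. What is called first, only, known or untested is meant among the compounds shown, and "the series" means these compounds.

Three compounds share a core in which a urea links a pyridinylmethyl group to a phenyl ring that carries a sulfonyl. Compound 1 `O=C(NCc1ccncc1)Nc1ccc(S(=O)(=O)c2ccc(Cl)cc2)cc1` gives 126 nM in an assay on isolated protein for activation of Nicotinamide phosphoribosyltransferase (Homo sapiens); on this read-out lower numbers stand for an effect already at smaller amounts and higher numbers for an effect only at larger amounts of compound. Compound 2 `O=C(NCc1ccncc1)Nc1ccc(S(=O)(=O)NCc2ccccc2)cc1` gives 102 nM. Compound 3 `O=C(NCc1ccncc1)Nc1ccc(S(=O)(=O)N2CCc3ccccc3C2)cc1` gives 142 nM, and its number sits within the scatter of both others, as shown by a 1.1-fold higher number from compound 1 to compound 3 (0.05 log units; within the scatter) and a 1.4-fold higher number from compound 2 to compound 3 (0.14 log units; within the scatter). Compound 4 `O=C(NCc1ccncc1)Nc1ccc(S(=O)(=O)c2cccc(Cl)c2)cc1` differs from compound 3 by 3-chlorophenyl in place of 1,2,3,4-tetrahydroisoquinolin-2-yl on a sulfonyl sulfur. Among the compounds with values here, the closest guide is compound 1, whose 4-chlorophenyl on the same sulfur gave a 1.1-fold higher number from compound 1 to compound 3 (0.05 log units; within the scatter); no measured step covers the change between the two chlorophenyl variants. A step no larger than the scatter is therefore expected, a 1.1-fold lower number from compound 3 to compound 4 (0.04 log units; within the scatter), and compound 4 is estimated at 130 nM, between 60 nM and 280 nM.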

Compound 4, half-maximal effective concentration: 69 nM
For compound 4 the middle estimate is 1.9-fold (0.28 log units) above the measured one; measured number inside the range.
By their numbers in this assay, from the lowest: compounds 4, 2, 1 and 3 (each within the scatter of the next, the first and the last beyond it).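

Within the data shown here, on the sulfonyl sulfur, 3-chlorophenyl gives the first step that passes the scatter (a 2.1-fold lower number from compound 3 to compound 4 (0.31 log units; beyond the scatter)), though the step is only modest. The other two steps stay within the scatter (a 1.5-fold lower number from compound 2 to compound 4 (0.17 log units; within the scatter); a 1.8-fold lower number from compound 1 to compound 4 (0.26 log units; within the scatter)), so the shift from 4-chlorophenyl to 3-chlorophenyl cannot be told apart from no change. Nothing available explains the modest step.

Still open, from the compounds shown here alone, is whether a methoxy group or a carboxylic acid on that phenyl ring, in place of the chlorine, would move the number further.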